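A few compounds are considered here, and "the series" means these few. Any claim that something is new, unique, unknown or untested is made for them only; others in the source may bear on it.

Measured in a physicochemical assay for solubility, read by HPLC, in phosphate buffer, at pH 7.4; a lower number here means a less soluble compound, a higher number a more soluble compound:
- compound 1 `O=C(Nc1ccccc1)Nc1cccc(Nc2nccc(Nc3ccc4[nH]ccc4c3)n2)c1`: 0.33 ug/mL
- compound 2 `O=C(Nc1ccccc1)Nc1cccc(Nc2nccc(Nc3ccc4cc[nH]c4c3)n2)c1`: 0.44 ug/mL

Compound 2 holds the highest of these two numbers, but the gap to compound 1 is within the scatter: the step is a 1.3-fold higher number from compound 1 to compound 2 (0.12 log units; within the scatter). Compound 3 `Cn1cc2ccc(Nc3ccnc(Nc4cccc(NC(=O)Nc5ccccc5)c4)n3)cc2n1` is still unmeasured, and it differs from compound 2 in one place: 2-methyl-2H-indazol-6-yl in place of 1H-indol-6-yl on a nitrogen on an aromatic ring. Going by the values given here, only that one measured step bears on this change, and it swaps 1H-indol-5-yl for 1H-indol-6-yl, so no measured step covers 2-methyl-2H-indazol-6-yl. No change beyond the scatter is therefore expected. The expected step is a 1.4-fold higher number from compound 2 to compound 3 (0.13 log units; within the scatter). Compound 3 is estimated at 0.6 ug/mL, with an expected range of 0.2 ug/mL to 2 ug/mL.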

Compound 3, solubility: 0.11 ug/mL
Compound 3: middle estimate off by 5.5-fold (0.74 log units), on the high side; the whole stated range lies above it.
By their numbers in this assay, from the lowest: compound 3; then compounds 1 and 2 (each within the scatter of the next).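

Between the two indolyl groups, the position on a nitrogen on an aromatic ring had shown no change beyond the scatter in this assay. Replacing either with 2-methyl-2H-indazol-6-yl does go beyond it, giving a 4.0-fold lower number from compound 2 to compound 3 (0.60 log units; beyond the scatter) and a 3.0-fold lower number from compound 1 to compound 3 (0.48 log units; beyond the scatter), so this position does respond to a change of group. Nothing measured here accounts for the step. Still open, as far as these compounds go, is how 1H-indazol-6-yl, without the methyl, or a group carrying an amine would read in this assay. The methyl and the ring nitrogen enter together in compound 3, so the step cannot be assigned to either.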